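The compounds below may be only part of what the source reports. "The series", "measured", "known", "first", "only" and "open" are said of these compounds alone.

Compound 1 `Cc1cccc(Cn2c(CN3CCN(C(=O)c4ccc(C(F)(F)F)cc4)CC3)nc3ccccc32)c1` gives 22.9% in an assay on isolated protein for inhibition of aldehyde dehydrogenase 1A1 (Homo sapiens), read by spectrophotometry, tested at 10 uM; on this read-out higher numbers stand for more inhibition at the one concentration tested (going by the name of the read-out) and lower numbers for less inhibition. Alongside it, compound 2 `O=C(C1CC1)N1CCN(Cc2nc3ccccc3n2Cc2ccc(F)cc2)CC1` gives 32.7% and compound 3 `CC(C)Cn1c(CN2CCN(C(=O)C3CC3)CC2)nc2ccccc21` gives 13.1%, so compound 1 stands second highest of the three, though its gaps to both neighbours lie within the scatter. Compound 4 `Cc1cccc(Cn2c(CN3CCN(C(=O)C(C)C)CC3)nc3ccccc32)c1` differs from compound 1 by isopropyl in place of 4-(trifluoromethyl)phenyl on a carbonyl carbon. Among the measured compounds shown here, the only measured step, a number 19.6 percentage points lower from compound 2 to compound 3 (beyond the scatter), concerns a different position and so bears on this change only loosely, yet it too swapped an aromatic group for isopropyl and lost a modest amount of inhibition. On that basis a small downward step, a number 8.9 percentage points lower from compound 1 to compound 4 (within the scatter), is expected for compound 4, roughly at the edge of the scatter. Compound 4 is therefore estimated at 14%, within a range from 2% to 30%.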

Compound 4, a percentage reported as inhibition, at one concentration (the size of the read-out at that concentration, not a potency): 87.2%
Estimate against measurement, compound 4: 73.2 percentage points below; the whole stated range lies below it.
By their numbers in this assay, from the lowest: compounds 3, 1 and 2 (each within the scatter of the next, the first and the last beyond it); then compound 4.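

In this assay, isopropyl in place of 4-(trifluoromethyl)phenyl on a carbonyl carbon gives a number 64.3 percentage points higher from compound 1 to compound 4 (beyond the scatter) and shows that this position can carry a large change in inhibition. Among the compounds shown here, the one earlier step, a number 19.6 percentage points lower from compound 2 to compound 3 (beyond the scatter), also put isopropyl in place of an aromatic group, but at another place and in the opposite direction, so this kind of swap has no single direction across the two positions. Nothing shown here explains the size of the new step. On these data alone, whether unsubstituted phenyl, tert-butyl or a longer chain on this carbonyl carbon would keep the inhibition remains open.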